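Cyclopropyl in place of allyl on the amide nitrogen

The source may report more compounds than this note shows. Statements on the series, on what has been measured and on what is new or still open speak of the compounds shown alone.

Measured compounds:
compound 1, `C=CCNC(=O)/C(C)=C(\C)c1cc(OC)c(OC)c(OC)c1`, 190 mg/kg
compound 2, `C/C(C(=O)NC1CC1)=C(/C)c1ccc(Br)cc1`, 130 mg/kg
compound 3, `C#CCNC(=O)/C(C)=C(\C)c1ccc(OC)cc1`, 150 mg/kg

Three amides sharing a core, each carrying a different group on the amide nitrogen and a different aromatic substitution, have been measured in a toxicity assay on the whole organism (strain Icem-CET (SPF Caw)) for cytotoxicity, with Mus musculus as the target; a higher number here means that more compound is needed for the effect, a lower number that less compound is needed. Compound 1 gives 190 mg/kg, compound 3 gives 150 mg/kg and compound 2 gives 130 mg/kg. Of these, compound 1 holds the highest figure, but its gap to compound 3 and its gap to compound 2 both lie within the usual scatter of this assay, so the three values cannot be placed in any order.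

Compound 4, `COc1cc(/C(C)=C(\C)C(=O)NC2CC2)cc(OC)c1OC`, has not yet been measured. It differs from compound 1 in one place: cyclopropyl in place of allyl on an amide-type nitrogen. For the measured compounds named here, compound 2 already carries a cyclopropyl on its amide nitrogen and gives a value within the scatter of compound 1, but compound 2 also differs in its aromatic part, so no clean step for this change is available. Going by the values given here, with nothing among the measured compounds pointing to a shift beyond the scatter, the step from compound 1 to compound 4 is expected to be small, a 1.2-fold lower number from compound 1 to compound 4 (0.07 log units; within the scatter), in either direction. Compound 4 is therefore estimated at 160 mg/kg, with a range from 90 mg/kg to 300 mg/kg.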

Compound 4, dose for half-maximal effect: > 800 mg/kg
Compound 4: a limit, no number; the forecaster's own chance of this, stated with the estimate: 5%; middle value at least 5.0-fold (0.69 log units) from the limit.
By their numbers in this assay, from the lowest: compounds 2, 3 and 1 (each within the scatter of the next). At a limit, above all of these: compound 4.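

For compound 4 the reading in this assay is a limit and not a number: the limit of > 800 mg/kg in this assay, at which 1 of the 4 values shown sits. Cyclopropyl in place of allyl on the amide nitrogen gives an at least 4.2-fold higher number from compound 1 to compound 4 (0.62 log units; beyond the scatter), so a swap between two groups with the same count of heavy atoms, all carbon, is enough to move the figure beyond the scatter on this core. The earlier compounds shown here could not show this: they offered no step between compounds differing in one place, and their values all lay within the scatter of one another, whereas this pair shows that the amide nitrogen is a position at which the dose in this whole-animal assay can change.

The limit leaves the full size of the step unknown, and the compounds shown do not tell whether the same swap would have a similar effect with the aromatic substitution of compound 3. They also leave open whether the step depends on the three-membered ring or on the loss of the double bond outside aromatic rings, a question that an n-propyl or a cyclobutyl group on the same nitrogen would bear on.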